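The compounds below may be only part of what the source reports. "The series", "measured", "known", "first", "only" and "open" are said of these compounds alone.

Values in a physicochemical assay for lipophilicity, measured as octanol-water partition (a lower number here means a more polar compound, a higher number a more lipophilic compound), for the measured compounds:

- compound 1 `CC1=C(C(=O)OCc2cccnc2)C(c2cccc(O)c2)C2=C(CCCC2=O)N1` with 1.21
- compound 2 `CC1=C(C(=O)OCc2cccnc2)C(c2ccccc2)C2=C(CCCC2=O)N1` with 2.35
- compound 3 `CC1=C(C(=O)OCc2cccnc2)C(c2ccc(Br)cc2)C2=C(CCCC2=O)N1` with 2.05

Compound 3 belongs to the upper pair of these numbers. Only a number 0.30 log units lower from compound 2 to compound 3 (within the scatter) sets it apart from the compound without a substituent on that ring, and this difference is too small to separate the two. On the other side, a number 0.84 log units higher from compound 1 to compound 3 (beyond the scatter) marks a clear gap from the hydroxy compound.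

In compound 4 `CC1=C(C(=O)OCc2cccnc2)C(c2ccc([N+](=O)[O-])cc2)C2=C(CCCC2=O)N1` the full count of the change from compound 3 reads nitro in place of bromo on an aromatic carbon in structural terms.

Within the data shown here, no measured step makes this exact exchange, so the evidence is indirect. The step from hydrogen to bromo stayed within the scatter, while removing hydroxy gave a number 1.14 log units higher from compound 1 to compound 2 (beyond the scatter) and shows that an oxygen-bearing group on this ring can shift the number far. Nitro also carries oxygen, so a modest fall is expected, smaller than that large step. The estimated step is a number 0.45 log units lower from compound 3 to compound 4 (beyond the scatter) in this assay on this reasoning.

Compound 4 is expected at 1.6 within an estimated range from 1.1 to 2.1 in this assay when measured.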

Compound 4, partition coefficient: 1.51
Beside the measured number, compound 4's estimate is 0.09 log units above it, and the stated range covers the measured number.
By their numbers in this assay, from the lowest: compounds 1 and 4 (each within the scatter of the next); then compounds 3 and 2 (each within the scatter of the next).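

Among these compounds, on the six-membered aromatic ring, at the place para to a large group, the earlier compounds offered only bromo and hydrogen, which could not be told apart in this assay. Nitro is the first group at this place to stand clear of both, with a number 0.54 log units lower from compound 3 to compound 4 (beyond the scatter) and a number 0.84 log units lower from compound 2 to compound 4 (beyond the scatter) as its two steps. The 4-nitrophenyl compound also cannot be separated from the 3-hydroxyphenyl compound, with a number 0.30 log units higher from compound 1 to compound 4 (within the scatter) as the step, and nothing shown here explains any of these differences.

On these data alone, it remains open how an amine, a carboxylic acid or a longer chain would read at this same place. As far as these compounds go, it is also open whether nitro and hydroxy would still sit this close if both were carried at the same place on the ring.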